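From Compound 1 to Compound 4: An Expected Limit

The source may report more compounds than this note shows. Statements on the series, on what has been measured and on what is new or still open speak of the compounds shown alone.

Compound 1 `O=C(CC1CCCCC1)N1CCN(c2nc(=O)c3cc(C(F)(F)F)cc([N+](=O)[O-])c3s2)CC1` was examined in an ADME assay on Vero cells (Chlorocebus sabaeus) for cytotoxicity, read by MTT assay, with a stated time of 72 h; a lower number here means that less compound is tolerated, a higher number that more compound is tolerated. There compound 1 reaches only the limit of the assay, reported as > 125000 nM. Two other compounds share the core of compound 1 and differ from it only in the group on the carbonyl carbon. Compound 2 `O=C(c1ccccc1Cl)N1CCN(c2nc(=O)c3cc(C(F)(F)F)cc([N+](=O)[O-])c3s2)CC1` likewise reaches only the limit, giving > 125000 nM in this assay. Compound 3 `O=C(C1CC1)N1CCN(c2nc(=O)c3cc(C(F)(F)F)cc([N+](=O)[O-])c3s2)CC1` also stops at the limit, with > 125000 nM. The steps among these three, a step that the two limits leave unreadable from compound 1 to compound 2, a step that the two limits leave unreadable from compound 1 to compound 3 and a step that the two limits leave unreadable from compound 2 to compound 3, cannot be read, since every value sits at the limit of > 125000 nM in this assay, at which 3 of the 3 values shown sit.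

Compound 4 `CCCCC(=O)N1CCN(c2nc(=O)c3cc(C(F)(F)F)cc([N+](=O)[O-])c3s2)CC1` has not yet been measured. It differs from compound 1 by propyl in place of cyclohexyl on a saturated chain carbon bound to a carbonyl carbon. Among the compounds with values here, none of the measured steps on the carbonyl carbon has a readable size, so no step bears on this change with a known magnitude; what is known is that every change tried there left the value at the limit. Compound 4 is therefore expected to remain at the limit as well, and the expected step of a number no higher from compound 1 to compound 4 (the limit leaves the size open) is none beyond the scatter. The estimate for compound 4 in this assay is 125000 nM, with a range from 60000 nM to 250000 nM.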

Compound 4, half-maximal cytotoxic concentration: > 125000 nM
Compound 4: a limit, no number; the forecaster's own chance of this, stated with the estimate: 80%; the middle value sits exactly at the limit.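

In this assay compound 4 gives > 125000 nM, which is a limit and not a number. Its steps from compounds 1, 2 and 3 therefore cannot be read: the limit of > 125000 nM in this assay, at which 4 of the 4 values shown sit.

The compounds shown leave open where the true values of these four compounds lie, and whether any group on the carbonyl carbon would give a readable number.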